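The compounds below may be only part of what the source reports. "The series", "measured", "known", "first", "only" and "open" are said of these compounds alone.

Series so far, all in a functional assay on A549 cells (Homo sapiens) for antiproliferative activity, read by MTT assay, with a stated time of 72 h; on this read-out lower numbers stand for stronger inhibition and higher numbers for weaker inhibition

- compound 1 `COc1cccc(N2C(=O)COc3ccc(-c4cnc(Cl)c(NS(=O)(=O)c5ccc(F)cc5)c4)cc32)c1` gives 32700 nM
- compound 2 `COc1ccc(N2C(=O)COc3ccc(-c4cnc(Cl)c(NS(=O)(=O)c5ccc(F)cc5)c4)cc32)cc1` gives 30400 nM
- compound 3 `O=C1COc2ccc(-c3cnc(Cl)c(NS(=O)(=O)c4ccc(F)cc4)c3)cc2N1c1ccc(F)cc1` gives 22300 nM

Compound 3 has the lowest number of the set, but this carries no ranking. The measured steps are a 1.4-fold lower number from compound 2 to compound 3 (0.13 log units; within the scatter) and a 1.5-fold lower number from compound 1 to compound 3 (0.17 log units; within the scatter), and both lie within the scatter. The three compounds therefore sit together on the numbers shown.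

The next structure is compound 4 `Cc1ccc(N2C(=O)COc3ccc(-c4cnc(Cl)c(NS(=O)(=O)c5ccc(F)cc5)c4)cc32)cc1`, which has methyl in place of fluoro on an aromatic carbon, para to a large group: methyl in place of fluoro on an aromatic carbon. The same difference, cut one bond further out, reads 4-fluorophenyl to 4-methylphenyl.

Among the compounds with values here, no measured compound carries this methyl group, so the expectation rests on neighbouring changes. The closest is a 1.4-fold lower number from compound 2 to compound 3 (0.13 log units; within the scatter), with fluoro in place of methoxy on an aromatic carbon. Exchanges of the whole aryl group on the amide-type nitrogen gave a 1.1-fold lower number from compound 1 to compound 2 (0.03 log units; within the scatter) and a 1.5-fold lower number from compound 1 to compound 3 (0.17 log units; within the scatter). All of these steps stay within the scatter, so no step beyond the scatter is expected in this assay, and no direction can be supported.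

The expected step is a 1.2-fold higher number from compound 3 to compound 4 (0.07 log units; within the scatter). For compound 4 the estimated value is 26000 nM, with an expected range from 14000 nM to 45000 nM.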

Compound 4, half-maximal inhibitory concentration: 30900 nM
For compound 4 the middle estimate is 1.2-fold (0.07 log units) below the measured one; measured number inside the range.
By their numbers in this assay, from the lowest: compounds 3, 2, 4 and 1 (each within the scatter of the next).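

In this assay, methyl in place of fluoro on an aromatic carbon, para to a large group, gives a 1.4-fold higher number from compound 3 to compound 4 (0.14 log units; within the scatter) and methyl in place of methoxy at the same place gives a 1.0-fold higher number from compound 2 to compound 4 (0.01 log units; within the scatter) while 4-methylphenyl in place of 3-methoxyphenyl on the amide-type nitrogen gives a 1.1-fold lower number from compound 1 to compound 4 (0.02 log units; within the scatter) in the same series. A carbon substituent at this position therefore joins fluoro and methoxy without separating from either, and the four aryl groups on that nitrogen, now including 4-methylphenyl, give no ranking among compound 1, compound 2, compound 3 and compound 4. No accompanying data bear on why this position shows so little response.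

Still open, on these data alone, is whether any group at this position can move the number beyond the scatter, for example an amine, a carboxylic acid or a longer chain such as butyl in place of methyl. Also open, as far as these compounds go, is whether the unsubstituted phenyl group on the same nitrogen, or a change away from this aryl group on the shared core, would separate from these four compounds.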